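Chloro in Place of Trifluoromethoxy on a Shared Core

The source may report more compounds than this note shows. Statements on the series, on what has been measured and on what is new or still open speak of the compounds shown alone.

Measured so far:
compound 1, `COc1ccc2cc(C(C)c3nnc4n3N=C(c3ccc(C(F)(F)F)cc3)CS4)ccc2c1`: 14800 nM
compound 2, `COc1ccc2cc(C(C)c3nnc4n3N=C(c3ccc(OC(F)(F)F)cc3)CS4)ccc2c1`: 16000 nM

In a functional assay on Huh-7 cells (Homo sapiens) for inhibition, read by sulforhodamine B assay, with a stated time of 72 h (a higher number here means a weaker inhibitor, a lower number a stronger inhibitor), compound 1 gives 14800 nM. In this assay compound 2 gives 16000 nM, the higher of the two numbers shown, though its only neighbour, compound 1, sits within the scatter. Within the data shown here, the single measured step, a 1.1-fold higher number from compound 1 to compound 2 (0.03 log units; within the scatter), exchanged one group for another on the same aromatic carbon without moving the number beyond the scatter.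

Compound 3, `COc1ccc2cc(C(C)c3nnc4n3N=C(c3ccc(Cl)cc3)CS4)ccc2c1`, differs from compound 2 in one place: chloro in place of trifluoromethoxy on an aromatic carbon. Among the measured compounds shown here, no measured step involves a chloro group, so the only guidance is a 1.1-fold higher number from compound 1 to compound 2 (0.03 log units; within the scatter), which shows that a change of the group at this place left the number essentially where it was. The step of a 1.1-fold lower number from compound 2 to compound 3 (0.03 log units; within the scatter) is therefore expected to stay within the scatter, with no clear direction. Compound 3 is estimated at 15000 nM, within a range from 6000 nM to 40000 nM.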

Compound 3, half-maximal inhibitory concentration: 5600 nM
Compound 3: the middle estimate sits 2.7-fold (0.43 log units) above what was measured; measured number outside the range, below it.
By their numbers in this assay, from the lowest: compound 3; then compounds 1 and 2 (each within the scatter of the next).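

Among these compounds, the earlier pair suggested that this aromatic carbon made little difference to the number, but that pair compared only two fluorine-bearing groups. In this assay, chloro in place of trifluoromethoxy gives a 2.9-fold lower number from compound 2 to compound 3 (0.46 log units; beyond the scatter), and chloro in place of trifluoromethyl gives a 2.6-fold lower number from compound 1 to compound 3 (0.42 log units; beyond the scatter), so the group at this place can shift the number, though both steps are modest. Compound 3 is the strongest inhibitor of the three, while compound 1 and compound 2 remain within the scatter of each other, and no evidence here accounts for the difference.

With only three groups shown at this place, it remains open whether the lower number is particular to chloro or would also appear with bromo or fluoro. Going by these compounds, how an amine or a carboxylic acid on the same carbon would compare also remains unknown.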